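Aryl amine variation on the shared core: trifluorophenyl step

The source may report more compounds than this note shows. Statements on the series, on what has been measured and on what is new or still open speak of the compounds shown alone.

Going by the values given here, compound 2 `Cc1ccc(S(=O)(=O)/N=C(/CCNC2=CC(=O)c3ccccc3C2=O)Nc2cccc(C)c2)cc1` gives 9060 nM in a functional assay on HeLa cells (Homo sapiens) for cytotoxicity, read by MTT assay, with a stated time of 48 h (on this read-out lower numbers stand for stronger inhibition and higher numbers for weaker inhibition), the second highest of the three numbers measured so far. Compound 1 `Cc1ccc(S(=O)(=O)/N=C(/CCNC2=CC(=O)c3ccccc3C2=O)Nc2ccc(F)cc2)cc1` gives 5890 nM and compound 3 `COc1ccc(N/C(CCNC2=CC(=O)c3ccccc3C2=O)=N\S(=O)(=O)c2ccc(C)cc2)c(OC)c1` gives 67600 nM. Among the compounds with values here, the step of a 1.5-fold higher number from compound 1 to compound 2 (0.19 log units; within the scatter) lies within the scatter, whereas an 11-fold higher number from compound 1 to compound 3 (1.06 log units; beyond the scatter) and a 7.5-fold higher number from compound 2 to compound 3 (0.87 log units; beyond the scatter) are the only changes beyond it. Compound 4 `Cc1ccc(S(=O)(=O)/N=C(/CCNC2=CC(=O)c3ccccc3C2=O)Nc2cc(F)c(F)c(F)c2)cc1` differs from compound 2 by 3,4,5-trifluorophenyl in place of 3-methylphenyl on an amine nitrogen. Within the data shown here, the one measured step that bears on this, a 1.5-fold higher number from compound 1 to compound 2 (0.19 log units; within the scatter), sets 4-fluorophenyl against 3-methylphenyl and shows nothing beyond the scatter; no measured compound carries three fluorines. The expected step of a 1.3-fold lower number from compound 2 to compound 4 (0.11 log units; within the scatter) is therefore small, with no clear direction. Compound 4 is estimated at 7000 nM, between 2500 nM and 20000 nM.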

Compound 4, half-maximal inhibitory concentration: 8580 nM
Beside the measured number, compound 4's estimate is 1.2-fold (0.09 log units) below it; the range from low to high includes it.
By their numbers in this assay, from the lowest: compounds 1, 4 and 2 (each within the scatter of the next); then compound 3.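

On the amine nitrogen, 3,4,5-trifluorophenyl falls in with 3-methylphenyl and 4-fluorophenyl: a 1.1-fold lower number from compound 2 to compound 4 (0.02 log units; within the scatter) and a 1.5-fold higher number from compound 1 to compound 4 (0.16 log units; within the scatter) both stay within the scatter. Only 2,4-dimethoxyphenyl stands apart, with a 7.9-fold lower number from compound 3 to compound 4 (0.90 log units; beyond the scatter) beyond it, and three fluorines in place of one bring no separation from compound 1. No supporting data on these compounds accompany the result. Open, going by these compounds, is whether a single methoxy group would carry the same loss as the pair in compound 3. Also open, on these data alone, is how an amine or a carboxylic acid on this aryl ring would read.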